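The source may hold more compounds than are shown below. What is called first, only, known or untested is meant among the compounds shown, and "the series" means these compounds.

Measured so far:
Compound 1 `CC1=CC[C@@H]([C@@](C)(O)CCCC(C)(C)NC(=S)NN)CC1`: in a functional assay on PCO3 cells (Homo sapiens) for cytotoxicity, read by sulforhodamine B assay (a higher number here means a weaker inhibitor of growth, a lower number a stronger inhibitor of growth), compound 1 gives > 100000 nM, which is a limit of the assay and not a number.
Compound 2 `CC1=CC[C@@H]([C@@](C)(O)CCCC(C)(C)NC(=S)N/N=C\c2ccc(C)cc2)CC1`: in this assay compound 2 gives 45700 nM.
Compound 3 `CC1=CC[C@@H]([C@@](C)(O)CCCC(C)(C)NC(=S)N/N=C\c2ccc(N(C)C)cc2)CC1`: in this assay compound 3 gives > 100000 nM, again a limit of the assay.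

Compound 1 therefore stands at the upper edge of what this assay reports; only a bound is known for it, and the same bound holds for compound 3 (the limit of > 100000 nM in this assay, at which 2 of the 3 values shown sit). The unmeasured compound is compound 4 `CC1=CC[C@@H]([C@@](C)(O)CCCC(C)(C)NC(=S)N/N=C\c2cccc(Cl)c2)CC1`. The change from compound 1 is a group of 9 heavy atoms (7 carbon, 1 nitrogen, 1 chlorine; one six-membered aromatic ring of carbon only) in place of one nitrogen atom, on an amide-type nitrogen.

For the measured compounds named here, one measured step bears directly on this: an at least 2.1-fold lower number from compound 1 to compound 2 (0.34 log units; beyond the scatter), where a closely related aryl hydrazone took the place of the same amino group and moved the number off the limit. The other step, an at least 2.1-fold higher number from compound 2 to compound 3 (0.34 log units; beyond the scatter), shows that a change of the substituent on the aromatic ring can send the number back to the limit, so the outcome depends on the ring substituent. Going by the values given here, no measured step covers a chlorine on that ring.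

Given the step from compound 1 to compound 2, compound 4 is expected to come off the limit by a comparable amount, an at least 2.2-fold lower number from compound 1 to compound 4 (0.34 log units; beyond the scatter). The estimate for compound 4 in this assay is 45000 nM, with a range of 15000 nM to 100000 nM.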

Compound 4, concentration for total growth inhibition: 37800 nM
For compound 4 the middle estimate is 1.2-fold (0.08 log units) above the measured one; measured number inside the range.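

In this assay, replacing the amino group of compound 1 with the hydrazone bearing 3-chlorophenyl gives an at least 2.6-fold lower number from compound 1 to compound 4 (0.42 log units; beyond the scatter), so leaving the limit is not confined to the 4-methylphenyl group of compound 2. Putting 3-chlorophenyl in place of 4-(dimethylamino)phenyl gives an at least 2.6-fold lower number from compound 3 to compound 4 (0.42 log units; beyond the scatter), while putting it in place of 4-methylphenyl gives a 1.2-fold lower number from compound 2 to compound 4 (0.08 log units; within the scatter); compound 2 and compound 4 therefore cannot be told apart here, and among the three aryl hydrazones shown only compound 3 remains at the limit. The steps from compound 1 and compound 3 give only a minimum size, because each starts from a limit and not a number: the limit of > 100000 nM in this assay, at which 2 of the 4 values shown sit.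

Compound 2 and compound 4 differ in both the ring substituent and its printed ring position, so a 4-chlorophenyl or 3-methylphenyl group would be needed to separate those two changes. Also open, going by these compounds, is how a carboxylic acid or a primary amine on the ring would read, and whether any aryl group moves the number clearly away from compound 2 and compound 4.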